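A few compounds are considered here, and "the series" means these few. Any claim that something is new, unique, unknown or untested is made for them only; others in the source may bear on it.

Three compounds of this series have numbers. Compound 1 `COc1cc(-c2cc(/C=C/C(=O)c3ccc(N)cc3)[nH]n2)cc(OC)c1OC` gives 1610 nM in a functional assay on ACHN cells (Homo sapiens) for inhibition, read by sulforhodamine B assay, with a stated time of 48 h; a lower number here means a stronger inhibitor of growth, a higher number a weaker inhibitor of growth. Compound 2 `COc1ccc(C(=O)/C=C/c2cc(-c3cc(OC)c(OC)c(OC)c3)n[nH]2)cc1OC` gives 1660 nM in this assay, and compound 3 `COc1cc(-c2cc(/C=C/C(=O)c3ccc(F)c(F)c3)[nH]n2)cc(OC)c1OC` gives 3260 nM. Compound 2 thus stands second highest of the three numbers; the smallest gap to it is a 1.0-fold higher number from compound 1 to compound 2 (0.01 log units; within the scatter) and the largest is a 2.0-fold higher number from compound 2 to compound 3 (0.29 log units; within the scatter). Compound 4 `COc1cc(C(=O)/C=C/c2cc(-c3cc(OC)c(OC)c(OC)c3)n[nH]2)cc(OC)c1OC` differs from compound 2 by methoxy in place of hydrogen on an aromatic carbon. The measured steps that bear on this change all alter the ring on the carbonyl carbon: a 1.0-fold higher number from compound 1 to compound 2 (0.01 log units; within the scatter), a 2.0-fold higher number from compound 1 to compound 3 (0.31 log units; beyond the scatter) and a 2.0-fold higher number from compound 2 to compound 3 (0.29 log units; within the scatter), none of them large. A step of similar modest size, or none beyond the scatter, is therefore expected in this assay, namely a 1.1-fold lower number from compound 2 to compound 4 (0.04 log units; within the scatter). Compound 4 is estimated at 1500 nM, with a range of 600 nM to 4000 nM.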

Compound 4, concentration for 50% growth inhibition: 1620 nM
Beside the measured number, compound 4's estimate is 1.1-fold (0.03 log units) below it; the measured number falls inside the stated range.
By their numbers in this assay, from the lowest: compounds 1, 4, 2 and 3 (each within the scatter of the next, the first and the last beyond it).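

Methoxy in place of hydrogen on an aromatic carbon, ortho to a methoxy group, gives no step beyond the scatter in this assay (a 1.0-fold lower number from compound 2 to compound 4 (0.01 log units; within the scatter)). The earlier steps shown here exchanged the whole ring on the carbonyl carbon, whereas this one adds a single group to a ring already carrying methoxy groups, and the number holds. No measurement on hand explains this result.

From the compounds shown here alone, whether a hydroxy group, a carboxylic acid or a longer chain such as butoxy at this place would also leave the number unchanged stays open. A single methoxy step cannot show how much size this position tolerates.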